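A few compounds are considered here, and "the series" means these few. Any claim that something is new, unique, unknown or untested is made for them only; others in the source may bear on it.

Compound 1 `CCOc1ccc([C@@H]2CC(=O)c3cc(CC=C(C)C)c(OC)cc3O2)cc1` gives 60%. Compound 2 `C#CCO/N=C1/C[C@@H](c2ccc(OC)cc2)Oc2cc(OC)c(CC=C(C)C)cc21` gives 41%. Compound 3 `COc1cc2c(cc1CC=C(C)C)[C@H](O)C[C@@H](c1ccc(O)cc1)O2` gives 13%.

These three numbers come from a functional assay on PC-3 cells (Homo sapiens) for inhibition, read by sulforhodamine B assay, with a stated time of 48 h, tested at 50 uM; on this read-out lower numbers stand for less inhibition of growth and higher numbers for more inhibition of growth at the one concentration tested. On them compound 1 stands highest: compound 2 lies below it by more than the scatter, and compound 3 lies lower still, also beyond the scatter.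

Compound 4 `CCCOc1ccc([C@@H]2CC(=O)c3cc(CC=C(C)C)c(OC)cc3O2)cc1` differs from compound 1 in a single place: methyl in place of hydrogen on a saturated chain carbon, two bonds along the chain from an oxygen on an aromatic ring. For the measured compounds named here, no measured pair in this set shows that change, so its effect is not known from these data. With compound 1 at 60%, the change is expected to move the number little, a number 2 percentage points higher from compound 1 to compound 4 (within the scatter), in no direction beyond the scatter. Compound 4 is therefore estimated at 62%, with a range from 45% to 78%.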

Compound 4, percent growth inhibition at one concentration: 54%
For compound 4 the middle estimate is 8 percentage points above the measured one; the measured number falls inside the stated range.
By their numbers in this assay, from the lowest: compound 3; then compound 2; then compounds 4 and 1 (each within the scatter of the next).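

In this assay, for the compounds shown here, the change from ethoxy to propoxy gives the first measured step at this position: a number 6 percentage points lower from compound 1 to compound 4 (within the scatter). On this read-out, the position therefore accepts the propoxy chain with no change in growth inhibition beyond the scatter. Nothing measured here explains this result.

The compounds shown leave open whether a longer chain, such as butoxy, would keep the number at this level. They also leave open what an amine or a carboxylic acid at the end of the chain would do.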